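The compounds below may be only part of what the source reports. "The series", "measured", "known", "first", "only" and "open" are said of these compounds alone.

Compound 2 `Cn1c(-c2ccccc2F)cnc1NC(=O)c1ccc(F)cc1` is the starting point of this account. In a toxicity assay on THP-1 cells (Homo sapiens) for inhibition (a lower number here means that less compound is tolerated, a higher number that more compound is tolerated), compound 2 gives > 100000 nM, which is a limit of the assay and not a number. Two companions stand beside it. Compound 1 `COc1ccc(-c2cnc(NC(=O)c3cnc[nH]3)n2C)cc1` gives > 100000 nM in this assay, again a limit. Compound 3 `COc1ccc(-c2cnc(NC(=O)c3cccc(OC)c3)n2C)cc1` gives > 100000 nM, also a limit. Going by the values given here, the only step among them, from compound 1 to compound 3, is a step that the two limits leave unreadable from compound 1 to compound 3, with 3-methoxyphenyl in place of 1H-imidazol-5-yl on a carbonyl carbon. All three results thus sit at the limit of > 100000 nM in this assay, at which 3 of the 3 values shown sit. The unmeasured compound 4 `Cn1c(-c2cccc(Cl)c2)cnc1NC(=O)c1ccc(F)cc1` differs from compound 2 by 3-chlorophenyl in place of 2-fluorophenyl on an aromatic carbon. Among the compounds with values here, no measured step touches that aromatic carbon, and the one measured step is unreadable, so there is nothing to lean on beyond the three limits. Within the data shown here, compound 4 is therefore expected to show essentially no step, a number no higher from compound 2 to compound 4 (the limit leaves the size open), in this assay. Compound 4 is estimated at 100000 nM, within 40000 nM to 300000 nM.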

Compound 4, half-maximal cytotoxic concentration: > 50000 nM
Compound 4 ended at the assay's limit; the forecaster's own chance of this, stated with the estimate: 85%; the middle value does not contradict the limit.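

In this assay compound 4 gives > 50000 nM, which is a limit and not a number. Compound 2 also sits at a limit, so the step between compound 2 and compound 4 cannot be read. The compounds shown leave open at what concentration, if any, each would reach half-maximal cytotoxicity.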